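Benzisoxazole methylsulfonamides in the maximal electroshock model

The compounds below may be only part of what the source reports. "The series", "measured", "known", "first", "only" and "open" are said of these compounds alone.

Measured so far:
compound 1 `CCNS(=O)(=O)Cc1noc2ccccc12` gives 39 mg/kg
compound 2 `CC(C)NS(=O)(=O)Cc1noc2ccccc12` gives 56 mg/kg
compound 3 `CCNS(=O)(=O)Cc1noc2ccc(F)cc12` gives 32 mg/kg

All three numbers come from a functional assay on the whole organism (strain STD-dd) with Mus musculus as the target, in the maximal electroshock model, with a stated time of 2 h; a lower number here means that less compound is needed, a higher number that more compound is needed for the effect. The series holds one shared core carrying a sulfonamide whose nitrogen bears a short alkyl chain, and the three measured compounds differ from one another at only two places.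

The first place is the chain on the sulfonamide nitrogen. Compound 1 and compound 2 differ by methyl in place of hydrogen on a saturated chain carbon bound to a saturated chain carbon and a sulfonamide nitrogen. In this assay the step is a 1.4-fold higher number from compound 1 to compound 2 (0.16 log units; within the scatter), which is within the scatter, so the two values cannot be ordered.

The second place is the aromatic ring of the core. Compound 1 and compound 3 differ by fluoro in place of hydrogen on an aromatic carbon. The step is a 1.2-fold lower number from compound 1 to compound 3 (0.09 log units; within the scatter), again within the scatter.

Compound 4 `CC(C)NS(=O)(=O)Cc1noc2ccc(F)cc12` has not been measured in this assay. It differs from compound 3 by methyl in place of hydrogen on a saturated chain carbon bound to a saturated chain carbon and a sulfonamide nitrogen, which is the same change, at the same place, as the one from compound 1 to compound 2; the two cores differ by the fluoro of compound 3, as given above. For the measured compounds named here, because the measured step for this change is a 1.4-fold higher number from compound 1 to compound 2 (0.16 log units; within the scatter), the corresponding step from compound 3 to compound 4 is expected to be of similar size, a 1.4-fold higher number from compound 3 to compound 4 (0.15 log units; within the scatter), with the wide range reflecting the scatter of the assay and the single precedent. Compound 4 is therefore estimated at 45 mg/kg, between 25 mg/kg and 80 mg/kg.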

Compound 4, dose for half-maximal effect: 38 mg/kg
Compound 4: middle estimate off by 1.2-fold (0.07 log units), on the high side, and the stated range covers the measured number.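

Ethyl to isopropyl on the fluoro-bearing core gives, in this assay, a 1.2-fold higher number from compound 3 to compound 4 (0.07 log units; within the scatter), and the comparison with the core without fluoro shows no dependence on the core that can be told apart from the scatter: the same change on two cores in this assay, a 1.4-fold higher number (0.16 log units; within the scatter) from compound 1 to compound 2 and a 1.2-fold higher number (0.07 log units; within the scatter) from compound 3 to compound 4, 1.2-fold (0.08 log units) apart, within the scatter of two such steps. Fluoro in place of hydrogen on an aromatic carbon, now with the isopropyl chain in place, gives a 1.5-fold lower number from compound 2 to compound 4 (0.17 log units; within the scatter), and this change too carries over within the scatter: the same change on two cores in this assay, a 1.2-fold lower number (0.09 log units; within the scatter) from compound 1 to compound 3 and a 1.5-fold lower number (0.17 log units; within the scatter) from compound 2 to compound 4, 1.2-fold (0.08 log units) apart, within the scatter of two such steps. For the compounds shown here, all of these steps are themselves within the scatter, so the agreement shows only that neither change moved the number detectably on either core; it does not show that a real effect of either change transfers from core to core, and with two cores per change it supports no rule for the wider series.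

The compounds shown leave open whether a longer chain such as n-butyl, or a ring such as cyclopropyl, on the sulfonamide nitrogen would give a step beyond the scatter. They also leave open whether chloro or methoxy in place of the fluoro would do so, and whether any such step would carry over between cores as these two changes appear to.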